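Two Bis-anilino Pyridinone Hydrazones and a Benzylthio Analogue

A few compounds are considered here, and "the series" means these few. Any claim that something is new, unique, unknown or untested is made for them only; others in the source may bear on it.

Compound 1: `Cc1cccc(NC2=C/C(=N/NC(N)=S)C(=O)N=C2Nc2cccc(C)c2)c1` — 8650 nM
Compound 2: `NC(=S)N/N=C1/C=C(Nc2ccc(Cl)cc2)C(Nc2ccc(Cl)cc2)=NC1=O` — 190 nM

Of the compounds shown here, two have been measured in a functional assay on HCT-116 cells (Homo sapiens) for antiproliferative activity, read by MTT assay, with a stated time of 72 h; on this read-out lower numbers stand for stronger inhibition and higher numbers for weaker inhibition. Compound 1 gives 8650 nM in this assay. Compound 2 gives 190 nM in this assay, the lowest of the two numbers; its nearest neighbour is compound 1, whose number is higher by a margin that lies beyond the usual scatter. Among the compounds with values here, the two compounds differ in the substituent on both anilino rings and in its position, so no single-point step between them is available.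

Compound 3, `N/C(=N\N=C1\C=C(Nc2ccc(Cl)cc2)C(Nc2ccc(Cl)cc2)=NC1=O)SCc1ccccc1`, keeps the shared core and both chloro-substituted anilino groups of compound 2 but carries a different terminus on the hydrazone: a group of 11 heavy atoms (8 carbon, 2 nitrogen, 1 sulfur; one six-membered aromatic ring of carbon only) in place of a group of 4 heavy atoms (1 carbon, 2 nitrogen, 1 sulfur; no ring), on a double-bonded nitrogen. Within the data shown here, no measured pair shows what such a change does here, so the direction of the step can only be guessed. A moderate step toward a higher number, a weaker inhibition, is expected for the step from compound 2 to compound 3 in this assay, a 2.4-fold higher number from compound 2 to compound 3 (0.37 log units; beyond the scatter), though a result within the scatter would not surprise. For compound 3 the value in this assay is estimated at 450 nM, with a range from 110 nM to 2500 nM.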

Compound 3, half-maximal inhibitory concentration: 9600 nM
Estimate against measurement, compound 3: 21-fold (1.33 log units) below; measured number above the stated range.
By their numbers in this assay, from the lowest: compound 2; then compounds 1 and 3 (each within the scatter of the next).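

With the shared core and both chloro-substituted anilino groups held fixed, only the hydrazone terminus changes, and in this assay the exchange of the group of 4 heavy atoms for the group of 11 heavy atoms, which brings in one six-membered aromatic ring of carbon only, comes with a 51-fold higher number from compound 2 to compound 3 (1.70 log units; beyond the scatter) as a large step. Within the data shown here, this is the first single-place reading in the set, and it shows that the number in this cell assay can depend strongly on what sits on this double-bonded nitrogen, at least for this one exchange. Nothing available here bears on the reason for the step, and the data give only its size and direction.

Going by these compounds, a single exchange cannot separate the contribution of the benzyl group from that of the altered sulfur-bearing terminus, so it remains open whether a smaller methylthio group, or a terminus with a carbonyl oxygen in place of the sulfur, would stay close to compound 2. On these data alone, it is also open whether the same exchange would give a similar step on the methyl-substituted anilino groups of compound 1.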